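The compounds below may be only part of what the source reports. "The series", "measured", "known", "first", "only" and "open" are said of these compounds alone.

Compound 1 `Fc1ccc(-c2ccc(-c3ccc(-c4nc5ccccc5[nH]4)cc3)cc2)cc1` is the reference point of this small series. In a functional assay on COLO 205 cells (Homo sapiens) for inhibition, read by sulforhodamine B assay (on this read-out lower numbers stand for stronger inhibition of growth and higher numbers for weaker inhibition of growth), compound 1 gives 100000 nM. Compound 2 `FC(F)(F)c1ccc(-c2ccc(-c3ccc(-c4nc5ccccc5[nH]4)cc3)cc2)cc1` differs from it in one place (trifluoromethyl in place of fluoro on an aromatic carbon), and in this assay compound 2 gives 33900 nM. That single change makes the step of a 2.9-fold lower number from compound 1 to compound 2 (0.47 log units; beyond the scatter), a modest gain for compound 2.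

Compound 3 `Cc1ccc2[nH]c(-c3ccc(-c4ccc(-c5ccc(F)cc5)cc4)cc3)nc2c1` keeps the outer 4-fluorophenyl of compound 1 and differs from it only in the core (methyl in place of hydrogen on an aromatic carbon). In this assay compound 3 gives 100000 nM, so the step of no change at the digits printed from compound 1 to compound 3 (within the scatter) shows that the methyl on the core leaves the read-out where compound 1 had it.

Compound 4 `Cc1ccc2[nH]c(-c3ccc(-c4ccc(-c5ccc(C(F)(F)F)cc5)cc4)cc3)nc2c1` has not yet been measured. It stands to compound 3 exactly as compound 2 stands to compound 1: the difference is trifluoromethyl in place of fluoro on an aromatic carbon, and the place of the change is described in the same words for both pairs, so this is the same change made on the core of compound 3 rather than on the core of compound 1. Because the step of a 2.9-fold lower number from compound 1 to compound 2 (0.47 log units; beyond the scatter) was modest and the core change no change at the digits printed from compound 1 to compound 3 (within the scatter) did nothing, compound 4 is expected to move from compound 3 by about a 2.9-fold lower number from compound 3 to compound 4 (0.46 log units; beyond the scatter). On that basis compound 4 is estimated at 35000 nM, with a likely range from 15000 nM to 100000 nM.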

Compound 4, concentration for 50% growth inhibition: 30600 nM
Compound 4: the middle estimate sits 1.1-fold (0.06 log units) above what was measured; measured number inside the range.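

On the core of compound 3, trifluoromethyl in place of fluoro in this assay gives a 3.3-fold lower number from compound 3 to compound 4 (0.51 log units; beyond the scatter), which matches the step seen on the core of compound 1: the same change on two cores in this assay, a 2.9-fold lower number (0.47 log units; beyond the scatter) from compound 1 to compound 2 and a 3.3-fold lower number (0.51 log units; beyond the scatter) from compound 3 to compound 4, 1.1-fold (0.04 log units) apart, within the scatter of two such steps The methyl in place of hydrogen, which left the read-out unchanged beside the fluoro group, also makes no difference beside the trifluoromethyl group, with a 1.1-fold lower number from compound 2 to compound 4 (0.04 log units; within the scatter): the same change on two cores in this assay, no change at the digits printed (within the scatter) from compound 1 to compound 3 and a 1.1-fold lower number (0.04 log units; within the scatter) from compound 2 to compound 4, 1.1-fold (0.04 log units) apart, within the scatter of two such steps Across these four compounds, then, each change keeps its size whichever form of the other site it is paired with, but this rests on one pair of cores and one pair of outer groups, so it does not show that the change would carry to other cores in the series, and it says nothing about why the two sites behave independently.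

On these data alone, it remains open whether other groups at the same place on the outer ring, such as an amine, a carboxylic acid or a longer chain, would extend the gain seen with trifluoromethyl or break the agreement between the two cores. As far as these compounds go, it is equally open whether anything larger than methyl on the core, such as an ethyl or a methoxy group, would still leave the read-out where it stands.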